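The compounds below may be only part of what the source reports. "The series", "measured", "known", "first", "only" and "open" are said of these compounds alone.

Measured in a functional assay on SK-OV-3 cells (Homo sapiens) for antiproliferative activity, read by MTT assay, with a stated time of 72 h; a lower number here means a stronger inhibitor, a higher number a weaker inhibitor:
- compound 1 `O=C(CCc1cccc2c1B(O)OC2)Nc1ccc(F)cc1`: 720 nM
- compound 2 `CC(C)c1cccc(NC(=O)CCc2cccc3c2B(O)OC3)c1`: 510 nM
- compound 3 `Cc1ccc(NC(=O)CCc2cccc3c2B(O)OC3)cc1Br`: 600 nM

Compound 2, at 510 nM, stands level with the other two: compound 1 and compound 3 both lie within the scatter of it, so the three values show no order. Compound 4 `O=C(CCc1cccc2c1B(O)OC2)Nc1cccc(-c2ccc(F)cc2)c1` carries one change from compound 2: 4-fluorophenyl in place of isopropyl on an aromatic carbon, meta to a large group. Among the measured compounds shown here, no measured pair isolates this change, so the expectation is loose. A modest step toward a lower number in this assay is expected, and the wide range also allows no step beyond the scatter. The expected step is a 2.0-fold lower number from compound 2 to compound 4 (0.31 log units; beyond the scatter). For compound 4 the estimated value is 250 nM, with an expected range of 50 nM to 800 nM.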

Compound 4, half-maximal inhibitory concentration: 93 nM
Beside the measured number, compound 4's estimate is 2.7-fold (0.43 log units) above it; low and high end bracket the measured number.
By their numbers in this assay, from the lowest: compound 4; then compounds 2, 3 and 1 (each within the scatter of the next).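

In this assay, the aromatic carbon that carries isopropyl in compound 2 accepts the larger 4-fluorophenyl, and this exchange gives a 5.5-fold lower number from compound 2 to compound 4 (0.74 log units; beyond the scatter). Among the compounds shown here, this is the only step so far that lies beyond the scatter, whereas the three earlier values stood level and showed no order. Nothing measured explains why the number falls with this change. Still open, as far as these compounds go, is whether the step depends on the fluorine or on the aromatic ring itself. Plain phenyl, a pyridine or a morpholine on this carbon would bear on that question.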